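The source may report more compounds than this note shows. Statements on the series, on what has been measured and on what is new or still open speak of the compounds shown alone.

Measured in a functional assay on SK-N-MC cells (Homo sapiens) for cytotoxicity, read by MTT assay; on this read-out higher numbers stand for weaker inhibition and lower numbers for stronger inhibition:
Compound 1 `CCCCOc1c(Br)cc(/C=C2\CCC/C(=C\c3cccc([N+](=O)[O-])c3)C2=O)cc1OC`: 25.4 ug/mL
Compound 2 `COc1cc(/C=C2\CCC/C(=C\c3ccc([N+](=O)[O-])cc3)C2=O)cc(Br)c1OC`: 9.86 ug/mL

Compound 2 holds the lower of the two numbers at 9.86 ug/mL, while compound 1 gives 25.4 ug/mL, a gap beyond the usual scatter. Within the data shown here, no measured pair here differs in one place only, so the data offer no direct step to lean on.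

Compound 3 `CCCCOc1c(Br)cc(/C=C2\CCC/C(=C\c3ccc([N+](=O)[O-])cc3)C2=O)cc1OC` has not yet been measured. It departs from compound 2 by propyl in place of hydrogen on a saturated chain carbon bound to an oxygen on an aromatic ring, with propyl in place of hydrogen on a saturated chain carbon bound to an oxygen on an aromatic ring, so that methoxy becomes butoxy. Compound 1 also carries butoxy and gives 25.4 ug/mL, which is the only measured hint about that chain. On that slender basis, a modest rise in the number in this assay, towards weaker inhibition, is expected, although a change within the scatter would be no surprise. The estimated step is a 1.5-fold higher number from compound 2 to compound 3 (0.18 log units; within the scatter). For compound 3 the estimated value is 15 ug/mL, with an expected range of 6.5 ug/mL to 32 ug/mL.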

Compound 3, half-maximal inhibitory concentration: 41.3 ug/mL
For compound 3 the middle estimate is 2.8-fold (0.44 log units) below the measured one; measured number above the stated range.
By their numbers in this assay, from the lowest: compound 2; then compounds 1 and 3 (each within the scatter of the next).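

In this assay, the change from methoxy to butoxy, on a saturated chain carbon bound to an oxygen on an aromatic ring, now has a direct reading with the rest of the structure held constant (a 4.2-fold higher number from compound 2 to compound 3 (0.62 log units; beyond the scatter)), and this step towards weaker inhibition lies beyond the usual scatter. The second pair isolates the other change, 4-nitrophenyl in place of 3-nitrophenyl on a double-bonded chain carbon bound to a double-bonded ring carbon, with butoxy present in both compounds (a 1.6-fold higher number from compound 1 to compound 3 (0.21 log units; within the scatter)), and this step lies within the scatter, so that compound 1 and compound 3 cannot be told apart in this assay. No measurement shown here accounts for the effect of the butoxy chain.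

On these data alone, whether butoxy has the same effect alongside 3-nitrophenyl remains open, as does whether the swap between the two nitrophenyl groups would read the same with methoxy in place of butoxy. As far as these compounds go, it is also open how the numbers would run for an intermediate chain such as ethoxy, a longer chain such as hexyloxy, or a chain ending in an amine or a carboxylic acid.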